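The source may report more compounds than this note shows. Statements on the series, on what has been measured and on what is new or still open speak of the compounds shown alone.

Compound 1, `C#CCSc1nnc(CC)n1N1C(=O)c2ccccc2C1=O`, gives in a functional assay on PC-3M cells (Homo sapiens) for cytotoxicity, read by MTT assay, with a stated time of 48 h (on this read-out lower numbers stand for stronger inhibition and higher numbers for weaker inhibition), a result that is only a limit of the assay, > 200000 nM.
Compound 2, `C=CCSc1nnc(CC)n1N1C(=O)c2ccccc2C1=O`, gives in this assay again only a limit, > 200000 nM.
Compound 3, `CCc1nnc(SCC(=O)c2ccccc2)n1N1C(=O)c2ccccc2C1=O`, gives in this assay likewise only a limit, > 200000 nM.

All three compounds share one core and differ only in the group carried on the saturated chain carbon bound to a sulfur. Because every result is a limit, compound 3 cannot be placed above or below the others: all three sit at the limit of > 200000 nM in this assay, at which 3 of the 3 values shown sit, and no order among them can be read. The steps a step that the two limits leave unreadable from compound 1 to compound 2, a step that the two limits leave unreadable from compound 1 to compound 3 and a step that the two limits leave unreadable from compound 2 to compound 3 are therefore of unreadable size; exchanging ethynyl for vinyl or for benzoyl produced nothing the assay could resolve.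

Compound 4, `CCc1nnc(SCC(=O)c2ccc(C)cc2)n1N1C(=O)c2ccccc2C1=O`, differs from compound 3 by methyl in place of hydrogen on an aromatic carbon. Going by the values given here, no measured step involves a methyl on an aromatic ring, so the only guidance is that every measured compound, compound 3 included, stopped at the limit. A single added carbon on the benzoyl group is not expected to move compound 4 off that limit. Compound 4 is therefore expected to give in this assay about 250000 nM, between 100000 nM and 1000000 nM, most probably reported again only as a limit. The estimated step that the limit leaves unreadable from compound 3 to compound 4 is expected to be none beyond the scatter.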

Compound 4, half-maximal inhibitory concentration: > 200000 nM
Compound 4: a limit, no number; the forecaster's own chance of this, stated with the estimate: 85%; the middle value lies beyond the limit too.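

Compound 4 also gives only a limit in this assay, so none of the steps to it from compound 1, compound 2 or compound 3 can be read: the limit of > 200000 nM in this assay, at which 4 of the 4 values shown sit.

The compounds shown leave open what concentration, if any, would give half-maximal inhibition for each of them, and whether any group at this place in the structure would bring a readable value.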